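From methoxy to amino at one aromatic carbon

This account rests on a few compounds, and the source may have more. Where it says the series, first, only, none or still open, it means among the compounds named here.

In a functional assay on PC-3 cells (Homo sapiens) for cytotoxicity, read by MTT assay, with a stated time of 48 h (a higher number here means a weaker inhibitor, a lower number a stronger inhibitor), compound 1 (`COc1ccc(-c2cn(C(C)=O)c(=O)n2-c2cc(OC)c(OC)c(OC)c2)cc1`) gives 19700 nM. Compound 2 (`COc1ccc(-c2cn(C(C)=O)c(=O)n2-c2cc(OC)c(OC)c(OC)c2)cc1OC`) stands at > 50000 nM, which is a limit of the assay and not a number. Its true position is therefore not known, and any step starting from compound 2 carries that uncertainty.

Compound 3 (`COc1ccc(-c2cn(C(C)=O)c(=O)n2-c2cc(OC)c(OC)c(OC)c2)cc1N`) has amino in place of methoxy on an aromatic carbon, ortho to a methoxy group and meta to a large group, turning 3,4-dimethoxyphenyl into 3-amino-4-methoxyphenyl (amino in place of methoxy on an aromatic carbon). For the measured compounds named here, only one measured step bears on this carbon: methoxy in place of hydrogen gave an at least 2.5-fold higher number from compound 1 to compound 2 (0.40 log units; beyond the scatter). Going by the values given here, the methoxy that arrived in that step leaves again in compound 3, but an amino takes its place rather than hydrogen, and no amino compound has yet been measured here. A lower number is therefore expected in this assay, returning roughly towards compound 1 at 19700 nM, with the size loosely held. The expected change is an at least 3.3-fold lower number from compound 2 to compound 3 (0.52 log units; beyond the scatter). For compound 3 the estimated value is 15000 nM, with an expected range from 3000 nM to 50000 nM.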

Compound 3, half-maximal inhibitory concentration: 21400 nM
Estimate against measurement, compound 3: 1.4-fold (0.15 log units) below; low and high end bracket the measured number.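

Amino in place of methoxy at this carbon gives an at least 2.3-fold lower number from compound 2 to compound 3 (0.36 log units; beyond the scatter) in this assay, which shows that the loss seen with methoxy does not come with every group placed here. Set against hydrogen at the same carbon, the amino group gives a 1.1-fold higher number from compound 1 to compound 3 (0.04 log units; within the scatter), so in this assay amino and hydrogen cannot be told apart at this position on the shared core, although amino brings a hydrogen-bond donor that the other two groups lack. Of the three groups, only methoxy stands apart, and how far it does so remains unknown, since the value of compound 2 is a limit of the assay and not a number: the limit of > 50000 nM in this assay, at which 1 of the 3 values shown sits.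

The compounds shown leave open whether the return to this level depends on the amino group itself or only on the methoxy being gone, a question that a hydroxyl, a fluorine or an acetamide at this carbon would help to separate. They also leave open whether any group at this carbon can bring the number clearly below compound 1 at 19700 nM and compound 3 at 21400 nM.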